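From compound 2 to compound 3: adding one fluoro

A few compounds are considered here, and "the series" means these few. Any claim that something is new, unique, unknown or untested is made for them only; others in the source may bear on it.

Compound 1 `Cc1ccccc1S(=O)(=O)c1ccc(CNC(=O)c2cc3cnccc3[nH]2)cc1`: 13 nM
Compound 2 `O=C(NCc1ccc(S(=O)(=O)c2ccccc2)cc1)c1cc2cnccc2[nH]1`: 18 nM

Both compounds were tested in a functional assay on A2780 cells (Homo sapiens) for inhibition, read by sulforhodamine B assay, with a stated time of 72 h; a lower number here means a stronger inhibitor, a higher number a weaker inhibitor. Among the measured compounds shown here, compound 2 sits at 18 nM, and its only neighbour, compound 1, sits at 13 nM. These two values cannot be told apart, so compound 2 has no meaningful rank yet.

Compound 3 `O=C(NCc1ccc(S(=O)(=O)c2ccc(F)cc2)cc1)c1cc2cnccc2[nH]1` keeps the structure of compound 2 except for one change, phenyl to 4-fluorophenyl: fluoro in place of hydrogen on an aromatic carbon. In words, this is fluoro in place of hydrogen on an aromatic carbon.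

For the measured compounds named here, only one measured step bears on this change: a 1.4-fold higher number from compound 1 to compound 2 (0.14 log units; within the scatter). It also exchanges a single group for hydrogen on an aromatic carbon, but that group is methyl, so it is only an indirect guide. Going by the values given here, no measured compound here carries a fluoro, which leaves the estimate uncertain. On this evidence, no step beyond the scatter is expected in this assay.

The expected change is a 1.1-fold lower number from compound 2 to compound 3 (0.05 log units; within the scatter).

Compound 3 is expected at about 16 nM, with an estimated range of 7 nM to 36 nM.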

Compound 3, half-maximal inhibitory concentration: 16 nM
The estimate for compound 3 equals the measured number at the digits printed, and the stated range covers the measured number.
By their numbers in this assay, from the lowest: compounds 1, 3 and 2 (each within the scatter of the next).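

In this assay, among the compounds shown here, the step of a 1.1-fold lower number from compound 2 to compound 3 (0.05 log units; within the scatter) is the first direct reading of a fluoro here: on an aromatic carbon para to a large group, this single added atom leaves compound 3 indistinguishable from compound 2. The wider exchange on the sulfonyl sulfur, 4-fluorophenyl in place of 2-methylphenyl, gives a 1.2-fold higher number from compound 1 to compound 3 (0.09 log units; within the scatter) and so also stays within the scatter, which means that all three compounds, with hydrogen, methyl or fluoro on this ring, cannot be separated in this cell test. Nothing is available to explain why these swaps leave the numbers so close together.

Going by these compounds, the three compounds cover only small groups on this ring, so it remains open whether an amine, a carboxylic acid or a longer chain in the same place would also stay within the scatter or would produce a real step. They also keep the amide, the sulfonyl group and the shared core the same throughout, so how much those parts contribute to the numbers in this assay cannot be judged from them.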